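Replacing the aryl group on the ether of compound 3

The source may report more compounds than this note shows. Statements on the series, on what has been measured and on what is new or still open speak of the compounds shown alone.

Going by the values given here, in a functional assay for inhibition, with Homo sapiens as the target (a higher number here means weaker binding, a lower number tighter binding), compound 3 `Cc1ccc(C#N)c(OC(C)(C)C2OCC(C/C=C\CCC(=O)O)C(c3cccnc3)O2)c1` gives 15.9 nM, the lowest of the three numbers so far. Compound 1 `N#Cc1ccccc1C1OCC(C/C=C\CCC(=O)O)C(c2cccnc2)O1` gives 245 nM, and compound 2 `O=C(O)CC/C=C\CC1COC(c2cccnc2)OC1c1cccnc1` gives 759 nM. Compound 4 `COc1ccccc1OC(C)(C)C1OCC(C/C=C\CCC(=O)O)C(c2cccnc2)O1` has 2-methoxyphenyl in place of 2-cyano-5-methylphenyl on an oxygen on a saturated carbon. Among the compounds with values here, no measured step varies this group directly. The nearest evidence is a 3.1-fold higher number from compound 1 to compound 2 (0.49 log units; beyond the scatter), which also loses a nitrile-bearing aryl group, but on a saturated ring carbon, so it bears only loosely. A similarly modest rise in this assay is therefore expected, an estimated 2.5-fold higher number from compound 3 to compound 4 (0.40 log units; beyond the scatter). Compound 4 is estimated at 40 nM, with an expected range of 13 nM to 120 nM.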

Compound 4, dissociation constant: 224 nM
For compound 4 the middle estimate is 5.6-fold (0.75 log units) below the measured one; the whole stated range lies below it.
By their numbers in this assay, from the lowest: compound 3; then compounds 4 and 1 (each within the scatter of the next); then compound 2.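

In this assay, 2-methoxyphenyl in place of 2-cyano-5-methylphenyl on an oxygen on a saturated carbon brings a 14-fold higher number from compound 3 to compound 4 (1.15 log units; beyond the scatter), so the low number of compound 3 depends strongly on the aryl group at this place. Going by these compounds alone, this is a large step, where the only earlier step, a 3.1-fold higher number from compound 1 to compound 2 (0.49 log units; beyond the scatter), was modest and concerned a different place. Nothing available bears on the reason for this loss.

The change alters the nitrile, the methyl and the methoxy together, so the share of each remains unresolved. Plain phenyl or 2-chlorophenyl on this oxygen would help separate them.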